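The source may report more compounds than this note shows. Statements on the series, on what has been measured and on what is new or still open speak of the compounds shown alone.

Measured compounds and values:

compound 1, `CCCCSc1nc(N)nc2c1ncn2/C=C1/CC1(CO)CO`: > 20000 nM
compound 2, `Nc1nc(NC2CCCCC2)c2ncn(/C=C3/CC3(CO)CO)c2n1`: "not determined" (no result reported)
compound 3, `CC(C)CSc1nc(N)nc2c1ncn2/C=C1/CC1(CO)CO`: "not determined" (no result reported)

The account follows an ADME assay on MOLT-3 cells (Homo sapiens) for cytotoxicity, with a stated time of 7 days (on this read-out higher numbers stand for lower toxicity in this test and lower numbers for higher toxicity in this test), across a small set of compounds. Compound 1 reaches only a limit of the assay, > 20000 nM, and no number. Compound 2 carries no result in this assay, and the same is true of compound 3, so compound 3 stands without any number of its own, beside one further value that is a limit and one further entry that gives no number, as the limit of > 20000 nM in this assay, at which 1 of the 3 values shown sits, shows.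

Compound 4, `Nc1nc(NCc2ccccc2)c2ncn(/C=C3/CC3(CO)CO)c2n1`, differs from compound 3 in one place: benzylamino in place of isobutylsulfanyl on an aromatic carbon.

Going by the values given here, no step between measured compounds is available, so nothing indicates the direction or size of the change that this exchange may bring in this assay; the only reading so far, that of compound 1, sits at the limit. On that basis compound 4 is expected to behave much like the measured set, with an estimate of 20000 nM, lying between 5000 nM and 60000 nM, and with a fair chance that only a limit is reported again.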

Compound 4, half-maximal cytotoxic concentration: > 20000 nM
Compound 4 gave a limit, no number; the forecaster's own chance of this, stated with the estimate: 65%; the middle value sits exactly at the limit.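

Compound 1 and compound 4 both give only a limit, not a number, in this assay, and no step can be read between them. The compounds shown leave open whether benzylamino and butylsulfanyl differ at all in this assay.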